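Biaryl benzylamines: diethylamino versus butylamino at the chain nitrogen

This account rests on a few compounds, and the source may have more. Where it says the series, first, only, none or still open, it means among the compounds named here.

Measured so far in an assay on isolated protein for binding affinity to 5-hydroxytryptamine receptor 1B (Homo sapiens); on this read-out higher numbers stand for weaker inhibition and lower numbers for stronger inhibition:
compound 1 `COc1ccccc1-c1cc(CN(C)C)ccc1Cl` gives 830 nM
compound 2 `CCCCNCc1ccc(Cl)c(-c2ccccc2OC)c1` gives > 10000 nM

For compound 2 the value is a limit of the assay, not a number (the limit of > 10000 nM in this assay, at which 1 of the 2 values shown sits). Compound 3 `CCN(CC)Cc1ccc(Cl)c(-c2ccccc2OC)c1` differs from compound 2 by diethylamino in place of butylamino on a saturated chain carbon bound to an aromatic carbon. Among the measured compounds shown here, the one measured step, an at least 12-fold higher number from compound 1 to compound 2 (1.08 log units; beyond the scatter), runs from a tertiary amine to a secondary one; no measured step covers diethylamino itself. Compound 3 is therefore expected to give a lower number, an at least 4.0-fold lower number from compound 2 to compound 3 (0.60 log units; beyond the scatter). Compound 3 is estimated at 2500 nM, within 600 nM to 10000 nM.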

Compound 3, inhibition constant: > 10000 nM
Compound 3 was reported as a limit; the forecaster's own chance of this, stated with the estimate: 30%; middle value at least 4.0-fold (0.60 log units) away from the limit.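

In this assay compound 3 gives > 10000 nM, a limit of the assay and not a number, and compound 2 stands at the same limit: the limit of > 10000 nM in this assay, at which 2 of the 3 values shown sit.

The step between compound 2 and compound 3 cannot be read from two limits. Diethylamino in place of dimethylamino on the saturated chain carbon gives an at least 12-fold higher number from compound 1 to compound 3 (1.08 log units; beyond the scatter), so a tertiary amine here does not by itself keep the value of compound 1.

Still open, as far as these compounds go, is whether a smaller change from dimethylamino, such as ethylmethylamino, stays measurable. Pyrrolidin-1-yl would show whether tying the two ethyl arms into a ring changes the result.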